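Swapping Carboxy for Hydroxymethyl in Two Related Series

The source may report more compounds than this note shows. Statements on the series, on what has been measured and on what is new or still open speak of the compounds shown alone.

Measured compounds:
Compound 1, `O=C(CCl)N1CCCC(n2nc(-c3ccc(Oc4ccccc4)cc3)cc2CO)C1`: 400 nM
Compound 2, `C/C=C/C(=O)Nc1cccc(Cn2nc(-c3ccc(Oc4ccccc4)cc3)cc2C(=O)O)c1`: 24100 nM
Compound 3, `O=C(O)c1cc(-c2ccc(Oc3ccccc3)cc2)nn1C1CCCN(C(=O)CCl)C1`: 2800 nM

All three were tested in a functional assay on Z-138 cells (Homo sapiens) for inhibition, read by luminescence and CellTiter-Glo, with a stated time of 72 h; on this read-out lower numbers stand for stronger inhibition and higher numbers for weaker inhibition. Compound 2 gives the highest number of the three, and compound 1 the lowest.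

Compound 3 and compound 1 share a core and differ in one place: hydroxymethyl in place of carboxy on an aromatic carbon. That change gave a 7.0-fold lower number from compound 3 to compound 1 (0.85 log units; beyond the scatter), a step beyond the usual scatter.

Compound 4, `C/C=C/C(=O)Nc1cccc(Cn2nc(-c3ccc(Oc4ccccc4)cc3)cc2CO)c1`, is not yet measured. It relates to compound 2 by the same kind of change: hydroxymethyl in place of carboxy on an aromatic carbon. The cores of compound 2 and compound 3 differ in more than one place, and that difference is not broken down here. The surroundings of the change also differ: in compound 3 the ring atom two ring bonds away bears a 1-((chloromethyl)carbonyl)piperidin-3-yl group, whereas in compound 2 it bears a large group of another kind.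

Within the data shown here, for compound 4 a step of a 6.0-fold lower number from compound 2 to compound 4 (0.78 log units; beyond the scatter) is expected, resting on compound 3 and compound 1 because a 7.0-fold lower number from compound 3 to compound 1 (0.85 log units; beyond the scatter) is the only precedent for this change. Compound 4 is therefore estimated at 4000 nM, with a range from 1500 nM to 12000 nM.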

Compound 4, half-maximal inhibitory concentration: 5700 nM
Beside the measured number, compound 4's estimate is 1.4-fold (0.15 log units) below it, within the range that was stated.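

On the second core, replacing carboxy with hydroxymethyl on the aromatic carbon gave a 4.2-fold lower number from compound 2 to compound 4 (0.63 log units; beyond the scatter) in this assay. Set beside the earlier case, the two steps point the same way and do not differ in size by more than repeated measurements can explain: the same change on two cores in this assay, a 7.0-fold lower number (0.85 log units; beyond the scatter) from compound 3 to compound 1 and a 4.2-fold lower number (0.63 log units; beyond the scatter) from compound 2 to compound 4, 1.7-fold (0.22 log units) apart, within the scatter of two such steps. For these two pairs, then, the change carried over from one core to the other with much the same effect, but two pairs cannot show that it will hold on every core in the series, and they say nothing about why the number falls.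

The compounds shown leave open whether an aminomethyl group, a methyl ester or a longer chain such as hydroxyethyl, placed where the hydroxymethyl sits, would give a similar step. They also leave open whether the step would persist on a core carrying neither the 1-((chloromethyl)carbonyl)piperidin-3-yl group nor the large group of compound 2.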